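The compounds below may be only part of what the source reports. "The series", "measured", "known", "first", "only" and "open" are said of these compounds alone.

Compound 1 `O=C(c1nc2sccn2c1Cl)N1CCN(C2CCCC2)C(=O)C1` stands at a limit in an ADME assay on Huh-7 cells (Homo sapiens) for cytotoxicity; a higher number here means that more compound is tolerated, a lower number that less compound is tolerated: compound 1 gives > 10000 nM, which is a limit of the assay and not a number. Compound 2 `Cc1cn2c(Cl)c(C(=O)N3CCN(C4CCCC4)C(=O)C3)nc2s1` likewise sits at a limit, as in this assay compound 2 gives > 10000 nM. The step from compound 1 to compound 2 therefore reads as a step that the two limits leave unreadable from compound 1 to compound 2, unreadable because of the limit of > 10000 nM in this assay, at which 2 of the 2 values shown sit. Compound 3 `O=C(c1nc2scc(C3CC3)n2c1Cl)N1CCN(C2CCCC2)C(=O)C1` differs from compound 1 by cyclopropyl in place of hydrogen on an aromatic carbon. Among the measured compounds shown here, no measured step gives a readable size for such a change, so compound 3 is expected to remain near the limit, and its estimated value in this assay is 15000 nM, between 5000 nM and 50000 nM, an expected step that the limit leaves unreadable from compound 1 to compound 3.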

Compound 3, half-maximal cytotoxic concentration: > 10000 nM
Compound 3: only a limit was reported; the forecaster's own chance of this, stated with the estimate: 70%; the middle value is on the limit's open side.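

Compound 3 also stands at a limit, so no size can be read for its step from compound 1: the limit of > 10000 nM in this assay, at which 3 of the 3 values shown sit. The compounds shown leave open whether cyclopropyl or methyl in place of hydrogen changes the tolerated concentration at all in this assay.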